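A few compounds are considered here, and "the series" means these few. Any claim that something is new, unique, unknown or untested is made for them only; others in the source may bear on it.

Measured so far:
- compound 1 `NS(=O)(=O)c1ccc(-c2cc(C(=O)N3CCCC3)nn2-c2ccc(C(F)(F)F)cn2)cc1` gives 8800 nM
- compound 2 `CCCC(=O)c1cc(-c2ccc(S(N)(=O)=O)cc2)nn1-c1ccc(Cl)cc1` gives 400 nM

In a physicochemical assay for solubility, read by HPLC, in phosphate buffer, measured as kinetic solubility, at pH 7.4 (a higher number here means a more soluble compound, a lower number a less soluble compound), compound 2 gives 400 nM as the lower of the two numbers, with compound 1 higher and beyond the scatter. Compound 3 `CN(C(=O)c1cc(-c2ccc(S(N)(=O)=O)cc2)nn1-c1ccc(Cl)cc1)C1CC1` differs from compound 2 by cyclopropyl(methyl)amino in place of propyl on a carbonyl carbon with cyclopropyl(methyl)amino in place of propyl on a carbonyl carbon. Within the data shown here, no measured pair isolates this change. Among the measured compounds shown here, the only guide is compound 1, which gives 8800 nM with an amide on its carbonyl carbon but differs elsewhere too. An upward step in this assay beyond the scatter is therefore expected, with a 5.0-fold higher number from compound 2 to compound 3 (0.70 log units; beyond the scatter) as the estimated size. The estimate for compound 3 is 2000 nM within a range of 600 nM to 7000 nM for now.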

Compound 3, solubility: 8000 nM
For compound 3 the middle estimate is 4.0-fold (0.60 log units) below the measured one, and the stated range ends below it.
By their numbers in this assay, from the lowest: compound 2; then compounds 3 and 1 (each within the scatter of the next).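

On a carbonyl carbon, cyclopropyl(methyl)amino in place of propyl gives, in this assay, a 20-fold higher number from compound 2 to compound 3 (1.30 log units; beyond the scatter). Among these compounds, this is the first single-place change, and it shows that this position alone can move the read-out by a large step with the rest of the structure held constant. Nothing available explains the size of this step.

Still open, going by these compounds, is whether a morpholine amide or a carboxylic acid on this carbonyl carbon would give a step of similar size. Also open, on these data alone, is whether the step carries over to the core of compound 1.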